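Replacing the ether ring of compound 3

The source may hold more compounds than are shown below. What is called first, only, known or untested is meant among the compounds shown, and "the series" means these compounds.

In an ADME assay on the whole organism (Rattus norvegicus) for pharmacokinetics, at a dose of 3 mg/kg by the oral route (a lower number here means less compound in the circulation, a higher number more compound in the circulation at the dose given), compound 3 `C[C@@H](Cn1c(=O)[nH]/c(=N\c2ccc(Oc3ccnc(F)c3)cc2)n(Cc2ccc(Cl)cc2)c1=O)C(=O)O` gives 1140 nM, the lowest of the three numbers measured. Compound 1 `Cc1ccc(Cn2c(Nc3ccc(OC(C)C)c(Cl)c3)nc(=O)n(CCC(=O)O)c2=O)cc1` gives 3400 nM, and compound 2 `C[C@@H](Cn1c(=O)[nH]/c(=N\c2ccc(Oc3ccccn3)cc2)n(Cc2ccc(Cl)cc2)c1=O)C(=O)O` gives 3210 nM. Compound 4 `C[C@@H](Cn1c(=O)[nH]/c(=N\c2ccc(Oc3ccsn3)cc2)n(Cc2ccc(Cl)cc2)c1=O)C(=O)O` carries 1,2-thiazol-3-yl in place of 2-fluoropyridin-4-yl on an oxygen on an aromatic ring. Among the measured compounds shown here, the only measured step at this place is a 2.8-fold lower number from compound 2 to compound 3 (0.45 log units; beyond the scatter), a modest one beyond the scatter, made by 2-fluoropyridin-4-yl replacing pyridin-2-yl. For the measured compounds named here, no measured compound carries the new ring, so that step offers only a rough scale. Losing 2-fluoropyridin-4-yl may give back part of that step, so a small rise in this assay is expected. The expected change is a 1.7-fold higher number from compound 3 to compound 4 (0.22 log units; within the scatter). For compound 4 the estimated value is 1900 nM, with a range of 700 nM to 5000 nM.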

Compound 4, maximal plasma concentration: 3130 nM
Estimate against measurement, compound 4: 1.6-fold (0.22 log units) below; the range from low to high includes it.
By their numbers in this assay, from the lowest: compound 3; then compounds 4, 2 and 1 (each within the scatter of the next).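

At this place on the oxygen, 1,2-thiazol-3-yl in place of 2-fluoropyridin-4-yl gives a 2.7-fold higher number from compound 3 to compound 4 (0.44 log units; beyond the scatter) in this assay, so the low number of compound 3 does not carry over to this other ring. With 1,2-thiazol-3-yl in place of pyridin-2-yl, the result is a 1.0-fold lower number from compound 2 to compound 4 (0.01 log units; within the scatter), so a five-membered and a six-membered ring stand level here. Nothing available explains why 2-fluoropyridin-4-yl stands apart from these two rings. Still open, as far as these compounds go, is whether the fluorine or the ring's point of attachment goes with the low number of compound 3. A plain pyridin-4-yl on the same oxygen would separate the two.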